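Swapping one aromatic group among compounds at a limit

This account rests on a few compounds, and the source may have more. Where it says the series, first, only, none or still open, it means among the compounds named here.

Values so far in an ADME assay on HepG2 cells (Homo sapiens) for cytotoxicity (on this read-out lower numbers stand for an effect already at smaller amounts and higher numbers for an effect only at larger amounts of compound), are these
- Compound 1 `Cc1ccc(S(=O)(=O)N[C@@H](CC(=O)NC(C)(C)C)C(=O)NCCNC(=O)c2cccc(C(C)C)c2)cc1` gives > 11000 nM as a limit
- Compound 2 `COc1cccc(C(=O)NCCNC(=O)[C@H](CC(=O)NC(C)(C)C)NS(=O)(=O)c2ccc(C)cc2)c1` gives > 11000 nM as a limit
- Compound 3 `Cc1ccc(S(=O)(=O)N[C@@H](CC(=O)NC(C)(C)C)C(=O)NCCNC(=O)c2cccc(C#N)c2)cc1` gives > 11000 nM as a limit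

Compound 2 stands at > 11000 nM in this assay, which is a limit and not a number. It has no exact position among its neighbours, and the whole picture so far is the limit of > 11000 nM in this assay, at which 3 of the 3 values shown sit, in plain terms.

Compound 4 `Cc1ccc(S(=O)(=O)N[C@@H](CC(=O)NC(C)(C)C)C(=O)NCCNC(=O)c2ccc(Cl)cc2)cc1` has not yet been measured. It differs from compound 2 in one place 4-chlorophenyl in place of 3-methoxyphenyl on a carbonyl carbon and this amounts to 4-chlorophenyl in place of 3-methoxyphenyl on a carbonyl carbon.

The nearest evidence comes from swaps of a single group on an aromatic carbon. These are a step that the two limits leave unreadable from compound 1 to compound 2 and a step that the two limits leave unreadable from compound 1 to compound 3 and a step that the two limits leave unreadable from compound 2 to compound 3 in turn. Among the measured compounds shown here, none of them has a readable size, and none of the measured compounds carries 4-chlorophenyl. All that can be said is that isopropyl, methoxy and cyano versions all reach the limit, so no clear shift and no direction is expected.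

The expected outcome is a step that the limit leaves unreadable from compound 2 to compound 4 in this estimate. For compound 4 the estimated value is 14000 nM with an expected range from 7000 nM to 30000 nM in this assay and a report as a limit alone is the likeliest result.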

Compound 4, half-maximal effective concentration: > 11000 nM
Compound 4 was reported as a limit; the forecaster's own chance of this, stated with the estimate: 85%; the middle value does not contradict the limit.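

In this assay compound 4 gives > 11000 nM, which is a limit and not a number. Among the compounds shown here, compound 1, compound 2, compound 3 and compound 4 all stand at a limit, so no step among them can be read: the limit of > 11000 nM in this assay, at which 4 of the 4 values shown sit. The compounds shown leave open how far their true values differ, and whether any aromatic group on this core gives a measurable value.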